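Cytotoxicity notes on a benzimidazole thioacetamide series

A few compounds are considered here, and "the series" means these few. Any claim that something is new, unique, unknown or untested is made for them only; others in the source may bear on it.

Measured so far:
- compound 1 `Cc1cc(C)cc(Cn2c(SCC(=O)Nc3ccccc3Br)nc3ccc(Cl)cc32)c1`: 174000 nM
- compound 2 `Cc1cc(C)cc(S(=O)(=O)n2c(SCC(=O)Nc3ccccc3Br)nc3ccc(Cl)cc32)c1`: 145000 nM
- compound 3 `Cc1cc(C)cc(Cn2c(SCC(=O)Nc3ccccc3[N+](=O)[O-])nc3ccccc32)c1`: 194000 nM

The read-out is an ADME assay on MT4 cells (Homo sapiens) for cytotoxicity; a lower number here means that less compound is tolerated, a higher number that more compound is tolerated. Compound 1 gives 174000 nM in this assay. Compound 2 gives 145000 nM in this assay. The change between them is (3,5-dimethylphenyl)sulfonyl in place of 3,5-dimethylbenzyl on an aromatic nitrogen and the step it made is a 1.2-fold lower number from compound 1 to compound 2 (0.08 log units; within the scatter), so within this pair the exchange on the aromatic nitrogen leaves the tolerated concentration essentially unchanged.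

Compound 3 gives 194000 nM in this assay. Its core and that of compound 1 differ in more than one place, and the difference between the two cores is not broken down here; their two values sit within the usual scatter of each other.

Compound 4 `Cc1cc(C)cc(S(=O)(=O)n2c(SCC(=O)Nc3ccccc3[N+](=O)[O-])nc3ccccc32)c1` is not yet measured. The change from compound 3 to compound 4 is (3,5-dimethylphenyl)sulfonyl in place of 3,5-dimethylbenzyl on an aromatic nitrogen, which is the same change as from compound 1 to compound 2, at a place described in the same words. Within the data shown here, only one earlier instance exists, so the expectation rests on that single pair. Because the step of a 1.2-fold lower number from compound 1 to compound 2 (0.08 log units; within the scatter) lay within the scatter, the step from compound 3 to compound 4 is estimated at a 1.2-fold lower number from compound 3 to compound 4 (0.08 log units; within the scatter), a shift of similar size. For compound 4 the estimated value in this assay is 162000 nM, with a range from 90000 nM to 290000 nM expected.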

Compound 4, half-maximal cytotoxic concentration: >= 26000 nM
Compound 4: a limit, no number; the forecaster's own chance of this, stated with the estimate: 15%; the middle value does not contradict the limit.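

In this assay, among these compounds, compound 4 gives >= 26000 nM as a limit of the assay and not a number, so no step from compound 3 to compound 4 can be read. Still open, from the compounds shown here alone, is whether (3,5-dimethylphenyl)sulfonyl in place of 3,5-dimethylbenzyl on the aromatic nitrogen changes the tolerated concentration on the core of compound 3 as little as it did between compound 1 and compound 2.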